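Swapping a methyl for hydrogen on compound 1

The compounds below may be only part of what the source reports. "The series", "measured", "known", "first", "only" and "open" are said of these compounds alone.

For the measured compounds named here, in a functional assay on SNU-638 cells (Homo sapiens) for cytotoxicity, read by MTT assay (on this read-out higher numbers stand for weaker inhibition and lower numbers for stronger inhibition), compound 1 (`COc1ccc(C(=O)/C=C/c2ccc(F)cc2)c(O)c1`) gives 18400 nM as the only number available, whereas for compound 2 (`COc1ccc(/C=C/C(=O)c2ccc(O)cc2)cc1Br`) the entry reads "not determined" (no result reported) and offers no comparison. Compound 3 (`O=C(/C=C/c1ccc(F)cc1)c1ccc(O)cc1O`) differs from compound 1 by hydrogen in place of methyl on an oxygen on an aromatic ring. Going by the values given here, no measured pair shows this methoxy to hydroxy change. In this assay the estimated 1.2-fold lower number from compound 1 to compound 3 (0.09 log units; within the scatter) stays within the usual scatter, so no clear move in either direction is expected. For compound 3 the estimated value is 15000 nM with an expected range from 6000 nM to 40000 nM as a working figure.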

Compound 3, half-maximal inhibitory concentration: 9430 nM
Estimate against measurement, compound 3: 1.6-fold (0.20 log units) above; low and high end bracket the measured number.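

For the compounds shown here, with a 2.0-fold lower number from compound 1 to compound 3 (0.29 log units; within the scatter) in this assay, the methoxy to hydroxy change now has a measured pair behind it, where the earlier compounds offered no comparison. At this place, on an oxygen on an aromatic ring, methyl and hydrogen give numbers that cannot be told apart beyond the usual scatter, though this rests on a single pair on the core of compound 1. Nothing at hand offers an explanation for this result.

As far as these compounds go, whether an ethoxy group, a longer chain on the same oxygen or an amine in its place would move the number stays open. So does whether the same change behaves alike on another core.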